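This account rests on a few compounds, and the source may have more. Where it says the series, first, only, none or still open, it means among the compounds named here.

Working notes on the series. Three measured compounds share one core and differ in a single group. Compound 1 `Oc1cccc(-c2cc(-c3ccc(Cl)cc3)nc(-c3cccs3)c2)c1` carries thiophen-2-yl, and in a functional assay on HCT-15 cells (Homo sapiens) for cytotoxicity, read by CCK-8 assay and cell counting, with a stated time of 2 days (on this read-out higher numbers stand for weaker inhibition and lower numbers for stronger inhibition), compound 1 gives 9280 nM. Compound 2 `Oc1cccc(-c2cc(-c3ccc(Cl)cc3)nc(-c3ccco3)c2)c1` carries furan-2-yl; in this assay compound 2 gives 10200 nM. Compound 3 `Oc1cccc(-c2cc(-c3ccc(Cl)cc3)nc(-c3ccsc3)c2)c1` carries thiophen-3-yl, and in this assay compound 3 gives 8850 nM. Compound 2 holds the highest of the three numbers, but every gap is small: a 1.1-fold higher number from compound 1 to compound 2 (0.04 log units; within the scatter), a 1.2-fold lower number from compound 2 to compound 3 (0.06 log units; within the scatter), and a 1.0-fold lower number from compound 1 to compound 3 (0.02 log units; within the scatter). All three exchanges of that group fall within the scatter, so the three compounds are indistinguishable on this read-out.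

Compound 4 `Oc1ccc(-c2cc(-c3ccc(Cl)cc3)nc(-c3ccco3)c2)cc1` keeps the furan-2-yl group and the 4-chlorophenyl group of compound 2 and alters the remaining group: 4-hydroxyphenyl in place of 3-hydroxyphenyl on an aromatic carbon. Among the compounds with values here, none of the measured steps concerns this group; each one swapped only the thiophen-2-yl, furan-2-yl or thiophen-3-yl group, and each stayed within the scatter. Within the data shown here, there is thus no direct precedent for this change, and the flatness of the series so far gives no reason to expect a step beyond the scatter in this assay in either direction. Compound 4 is therefore estimated at 10000 nM, with an expected range from 4000 nM to 25000 nM. The step this estimate implies is a 1.0-fold lower number from compound 2 to compound 4 (0.01 log units; within the scatter), an expectation rather than a measurement.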

Compound 4, half-maximal inhibitory concentration: 7020 nM
Beside the measured number, compound 4's estimate is 1.4-fold (0.15 log units) above it; low and high end bracket the measured number.
By their numbers in this assay, from the lowest: compounds 4, 3, 1 and 2 (each within the scatter of the next).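

In this assay, 4-hydroxyphenyl in place of 3-hydroxyphenyl, on the aromatic carbon opposite the ring nitrogen, gives a 1.5-fold lower number from compound 2 to compound 4 (0.16 log units; within the scatter) and so leaves the read-out unresolved for this exchange. Within the data shown here, this is the first look at this position: the earlier steps touched only the thiophen-2-yl, furan-2-yl and thiophen-3-yl group, and the flat picture now extends to a second position, though for one exchange only, made with furan-2-yl held constant and with the two compounds having the same atoms, joined differently. No supporting measurement bears on this result.

The compounds shown leave open whether the hydroxy group matters at all on this ring, since every compound carries it, and a methoxy group, an amine or a carboxylic acid in its place would test that directly. Also open, from the compounds shown here alone, are the 4-chlorophenyl group, which stays the same throughout, and whether 4-hydroxyphenyl gives the same picture when paired with thiophen-2-yl or thiophen-3-yl.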